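Sulfonylurea tail variation on a shared diisopropylphenyl core

The compounds below may be only part of what the source reports. "The series", "measured", "known", "first", "only" and "open" are said of these compounds alone.

Of the compounds shown here, three built on one core have been measured in an assay on liver for inhibition of sterol O-acyltransferase 1 (Rattus norvegicus), using microsomes; a higher number here means a weaker inhibitor, a lower number a stronger inhibitor. Compound 1 `CCN(CC)S(=O)(=O)NC(=O)Nc1c(C(C)C)cccc1C(C)C` gives 2500 nM and stands second highest of the three numbers. Its nearest neighbour is compound 2 `C=CCN(CC)S(=O)(=O)NC(=O)Nc1c(C(C)C)cccc1C(C)C`, which gives 2100 nM; the step of a 1.2-fold lower number from compound 1 to compound 2 (0.08 log units; within the scatter) is within the scatter. The furthest is compound 3 `CC(C)c1cccc(C(C)C)c1NC(=O)NS(=O)(=O)N1CCCCC1`, which gives 17000 nM; the step of a 6.8-fold higher number from compound 1 to compound 3 (0.83 log units; beyond the scatter) is beyond the scatter, as is an 8.1-fold higher number from compound 2 to compound 3 (0.91 log units; beyond the scatter).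

The next compound, compound 4 `CC(C)CN(CC(C)C)S(=O)(=O)NC(=O)Nc1c(C(C)C)cccc1C(C)C`, has not yet been measured in this assay. Its difference from compound 1 is diisobutylamino in place of diethylamino on a sulfonyl sulfur. For the measured compounds named here, two measured steps bear on this change, since both alter the same amine on the sulfonyl sulfur. Extending one open chain, as in a 1.2-fold lower number from compound 1 to compound 2 (0.08 log units; within the scatter), left the number essentially unchanged; closing the two chains into a ring, as in a 6.8-fold higher number from compound 1 to compound 3 (0.83 log units; beyond the scatter), gave a modest weakening. Going by the values given here, compound 4 keeps open chains, only longer and branched, so the closer precedent is the first step, and no step beyond the scatter is firmly expected, though the larger change leaves room for movement in either direction.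

Compound 4 is therefore expected to give about 2000 nM in this assay, within a range of 500 nM to 8000 nM, corresponding to an estimated step of a 1.3-fold lower number from compound 1 to compound 4 (0.10 log units; within the scatter).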

Compound 4, half-maximal inhibitory concentration: 420 nM
For compound 4 the middle estimate is 4.8-fold (0.68 log units) above the measured one; the measured number lies below the stated range.
By their numbers in this assay, from the lowest: compound 4; then compounds 2 and 1 (each within the scatter of the next); then compound 3.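

At this position on the sulfonyl sulfur, open chains do not always leave the number in this assay unchanged: diisobutylamino in place of diethylamino gives a 6.0-fold lower number from compound 1 to compound 4 (0.77 log units; beyond the scatter), and in place of allyl(ethyl)amino it gives a 5.0-fold lower number from compound 2 to compound 4 (0.70 log units; beyond the scatter). The contrast with the ring is larger still, with diisobutylamino in place of piperidin-1-yl giving a 40-fold lower number from compound 3 to compound 4 (1.61 log units; beyond the scatter), so compound 4 is the strongest inhibitor of the four and this one position covers a wide span of the assay's numbers. Nothing available explains why the diisobutylamino group has this effect.

The compounds shown leave open whether the improvement follows the branching of the chains or simply their greater length, a question that a straight-chain dibutylamino group on the same sulfonyl sulfur would help to separate. They also leave open how far the trend runs with still larger open chains such as dihexylamino, and whether a ring such as morpholin-4-yl would stay as weak as the piperidin-1-yl of compound 3.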